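A Chain Swap on a Weak Inhibitor

The source may hold more compounds than are shown below. What is called first, only, known or untested is meant among the compounds shown, and "the series" means these compounds.

In a functional assay on HT-29 cells (Homo sapiens) for inhibition, read by MTT assay, with a stated time of 72 h (a lower number here means a stronger inhibitor, a higher number a weaker inhibitor), compound 1 (`CCC(C)NC(=C\C(=O)/C=C/c1ccc(O)c(OC)c1)/C=C/c1ccc(O)c(OC)c1`) stands at > 25000 nM, which is a limit of the assay and not a number. Compound 2 (`CC(C)CNC(=C\C(=O)/C=C/c1ccc(O)cc1)/C=C/c1ccc(O)cc1`), which also carries isobutyl, gives 20100 nM in this assay, so it too is a weak inhibitor. Compound 3 (`COc1cc(/C=C/C(=O)/C=C(/C=C/c2ccc(O)c(OC)c2)NCC(C)C)ccc1O`) keeps the core of compound 1 and changes one group: isobutyl in place of sec-butyl on an amine nitrogen. With the same atoms only joined differently, the expected step is small, an at least 1.2-fold lower number from compound 1 to compound 3 (0.09 log units; that floor lies within the scatter). Compound 3 is estimated at 20000 nM, within an expected range of 9000 nM to 40000 nM.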

Compound 3, half-maximal inhibitory concentration: 24500 nM
The estimate for compound 3 lay 1.2-fold (0.09 log units) below the measured number, and the stated range covers the measured number.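

Exchanging sec-butyl for isobutyl on the amine nitrogen gives an at least 1.0-fold lower number from compound 1 to compound 3 (0.00 log units; that floor lies within the scatter), so this change shows no gain in inhibition. Compound 1 stands at a limit of the assay and not a number, so the step has only a floor: the limit of > 25000 nM in this assay, at which 1 of the 3 values shown sits. With isobutyl on this nitrogen, compound 3 gives 24500 nM in this assay and remains a weak inhibitor.

The compounds shown leave open whether a much different group on this nitrogen, such as a longer chain, a cyclohexyl ring or a chain ending in a carboxylic acid, would move the number.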